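This account rests on a few compounds, and the source may have more. Where it says the series, first, only, none or still open, it means among the compounds named here.

In a functional assay on FM3A cells (Mus musculus) for antiproliferative activity, with a stated time of 48 h (a lower number here means a stronger inhibitor, a higher number a weaker inhibitor), compound 1 `C=C(Br)C(=O)Nc1ccc(/C=C/C(=O)c2ccc(Cl)cc2)cc1` gives 1300 nM, and compound 2 `C=C(Br)C(=O)Nc1ccc(/C=C/C(=O)c2ccc(I)cc2)cc1` gives 8300 nM, the higher of the two numbers. Compound 3 `C=C(Br)C(=O)Nc1ccc(/C=C/C(=O)c2ccc(C)cc2)cc1` differs from compound 2 by methyl in place of iodo on an aromatic carbon, with methyl in place of iodo on an aromatic carbon. Among the compounds with values here, only one measured step bears on this change: a 6.4-fold higher number from compound 1 to compound 2 (0.81 log units; beyond the scatter), a modest step that also involves the iodo group. Within the data shown here, no methyl compound has been measured, so a modest fall is expected, and the expected change is a 3.3-fold lower number from compound 2 to compound 3 (0.52 log units; beyond the scatter). Compound 3 is estimated at 2500 nM, within an expected range of 800 nM to 8000 nM.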

Compound 3, half-maximal inhibitory concentration: 2100 nM
For compound 3 the middle estimate is 1.2-fold (0.08 log units) above the measured one; low and high end bracket the measured number.
By their numbers in this assay, from the lowest: compounds 1 and 3 (each within the scatter of the next); then compound 2.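

In this assay, methyl at this position, on an aromatic carbon para to a large group, gives a 4.0-fold lower number from compound 2 to compound 3 (0.60 log units; beyond the scatter) and so does not share the weaker result of the iodo compound. Against chloro, methyl gives a 1.6-fold higher number from compound 1 to compound 3 (0.21 log units; within the scatter) and the two groups cannot be told apart here, which leaves iodo as the only one of the three that stands out. Nothing measured on these compounds bears on the reason for this. Still open, going by these compounds, is whether a fluoro, a methoxy, an amine or a carboxylic acid at this position would stay with chloro and methyl or fall with iodo.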